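Nitro in place of bromo on the anilide of compound 3

A few compounds are considered here, and "the series" means these few. Any claim that something is new, unique, unknown or untested is made for them only; others in the source may bear on it.

Compound 3 `COc1ccc(-c2nnsc2SCC(=O)Nc2ccccc2Br)cc1` stands at a limit of an ADME assay on MT4 cells (Homo sapiens) for cytotoxicity (a higher number here means that more compound is tolerated, a lower number that less compound is tolerated), rather than at a number. In this assay compound 3 gives > 286000 nM, which is the limit of > 286000 nM in this assay, at which 1 of the 3 values shown sits. Compound 1 `COc1ccc(-c2nnsc2SCC(=O)Nc2ccccc2Cl)cc1` also sits at a limit in this assay. Compound 1 gives > 318000 nM, which is the limit of > 318000 nM in this assay, at which 1 of the 3 values shown sits. Going by the values given here, the only number without a sign comes from compound 2 `COc1ccc(-c2nnsc2SCC(=O)Nc2ccc(C)cc2Br)cc1`, which in this assay gives 249000 nM.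

The measured steps are small or unreadable: an at least 1.2-fold lower number from compound 1 to compound 2 (0.10 log units; that floor lies within the scatter); an at least 1.1-fold higher number from compound 2 to compound 3 (0.06 log units; that floor lies within the scatter); a step that the two limits leave unreadable from compound 1 to compound 3. So within the series, swapping halogens or removing the methyl on the anilide ring leaves this assay close to its upper limit.

Compound 4 `COc1ccc(-c2nnsc2SCC(=O)Nc2ccccc2[N+](=O)[O-])cc1` differs from compound 3 by nitro in place of bromo on an aromatic carbon. Among the compounds with values here, no measured step touches a nitro group, so the bearing steps are only those on the same ring, all within the scatter. The expectation is therefore no step beyond the scatter: compound 4 is expected to show an at least 1.1-fold lower number from compound 3 to compound 4 (0.05 log units; that floor lies within the scatter), with a good chance that this assay again reports only a limit.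

Compound 4 is estimated at 250000 nM in this assay, with a range from 120000 nM to 320000 nM.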

Compound 4, half-maximal cytotoxic concentration: >= 280000 nM
Compound 4 ended at the assay's limit (the forecaster's own chance of this, stated with the estimate: 55%); middle value at least 1.1-fold (0.04 log units) from the limit.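

Compound 4 sits at a limit in this assay: the limit of >= 280000 nM in this assay, at which 1 of the 4 values shown sits. The position ortho to a large group therefore takes nitro, with 3 heavy atoms and 2 hydrogen-bond acceptors, as well as the single-atom halogens, without any readable drop in the tolerated concentration, so the tolerance seen so far is no longer confined to bromo and chloro at this position. Going by these compounds alone, the one readable step is an at least 1.1-fold higher number from compound 2 to compound 4 (0.05 log units; that floor lies within the scatter), while the steps to compound 4 from compound 3 and from compound 1 cannot be read, with limits at both ends.

As far as these compounds go, compound 1, compound 3 and compound 4 give no number, so their order in this assay and the true size of the bromo-to-nitro change stay open. Also open, from the compounds shown here alone, is whether an amine or a carboxylic acid at this same position would bring the read-out down to a measurable number, as compound 2 gives with its added methyl, or would leave it at a limit as well.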